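The source may hold more compounds than are shown below. What is called first, only, known or untested is meant among the compounds shown, and "the series" means these compounds.

Compound 1 `Cc1ccc(-c2cn(C/C=C3\OC(=O)C(OCc4ccccc4)=C3OCc3ccccc3)nn2)cc1`: > 100000 nM
Compound 2 `CC(C)(C)c1cn(C[C@H](O)[C@H]2OC(=O)C(OCc3ccccc3)=C2OCc2ccccc2)nn1`: 29200 nM

In a functional assay on HepG2 cells (Homo sapiens) for antiproliferative activity, read by MTT assay, with a stated time of 72 h (on this read-out higher numbers stand for weaker inhibition and lower numbers for stronger inhibition), compound 1 gives > 100000 nM, which is a limit of the assay and not a number. Compound 2, with a different side chain, gives 29200 nM. Compound 3 `O=C1O/C(=C\Cn2cc(-c3cccc(O)c3)nn2)C(OCc2ccccc2)=C1OCc1ccccc1` keeps the core of compound 1 but carries 3-hydroxyphenyl in place of 4-methylphenyl on an aromatic carbon. For the measured compounds named here, no measured pair tests this exchange, so only a modest move towards stronger inhibition is expected, an estimated step of an at least 1.4-fold lower number from compound 1 to compound 3 (0.15 log units; that floor lies within the scatter). For compound 3 the estimated value is 70000 nM, with an expected range of 20000 nM to 200000 nM.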

Compound 3, half-maximal inhibitory concentration: 61700 nM
Beside the measured number, compound 3's estimate is 1.1-fold (0.05 log units) above it; the measured number falls inside the stated range.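

With 3-hydroxyphenyl in place of 4-methylphenyl, compound 3 gives a number on the shared core in this assay, and the exchange reads as an at least 1.6-fold lower number from compound 1 to compound 3 (0.20 log units; that floor lies within the scatter). The value of compound 1 is a limit of the assay and not a number, so this step has only a floor: the limit of > 100000 nM in this assay, at which 1 of the 3 values shown sits.

The compounds shown leave open how an amine or a carboxylic acid in place of the hydroxy group on that phenyl ring would read on this core. They also leave open how far the exchange reaches beyond this single pair.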